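Removing the hydroxy from compound 3: the expected tolerance

The source may hold more compounds than are shown below. What is called first, only, known or untested is meant among the compounds shown, and "the series" means these compounds.

Compound 1 `C=C(C(=O)O)[C@@H]1C[C@@]2(C)C(=CC1=O)C=C[C@H](O)[C@@H]2C`: in an ADME assay on RAW264.7 cells (Mus musculus) for cytotoxicity, read by MTT assay, with a stated time of 24 h (a lower number here means that less compound is tolerated, a higher number that more compound is tolerated), compound 1 reaches only the assay limit, > 50000 nM.
Compound 2 `C=C(C(=O)O)[C@@H]1C[C@@]2(C)C(=CC1=O)C=C[C@H](OC(=O)CC/C=C/C)[C@@H]2C`: in this assay compound 2 likewise gives only a limit, > 50000 nM.
Compound 3 `C=C(CO)[C@@H]1C[C@@]2(C)C(=C[C@H](O)C[C@@H]2C)C[C@H]1O`: in this assay compound 3 also stops at a limit, > 50000 nM.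

Compound 3 thus stands where every measured compound stands, at the limit of > 50000 nM in this assay, at which 3 of the 3 values shown sit, and its position among them cannot be ordered. Among the measured compounds shown here, the one measured step, a step that the two limits leave unreadable from compound 1 to compound 2, is unreadable for the same reason, so no step of known size bears on the change now considered.

Compound 4 `C=C(C)[C@@H]1C[C@@]2(C)C(=C[C@H](O)C[C@@H]2C)C[C@H]1O` differs from compound 3 as follows: hydrogen in place of hydroxy on a saturated chain carbon bound to a double-bonded chain carbon. The change is small, a single hydroxy leaving and a hydrogen entering on a saturated chain carbon bound to a double-bonded chain carbon. Nothing measured shows that such a change moves tolerance in either direction, and all three compounds sit at the limit. He therefore expects the step that the limit leaves unreadable from compound 3 to compound 4 to be nil beyond the scatter. His estimate for compound 4 in this assay is 80000 nM, within 30000 nM to 250000 nM, most likely again reported as a limit.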

Compound 4, half-maximal cytotoxic concentration: > 50000 nM
Compound 4 ended at the assay's limit (the forecaster's own chance of this, stated with the estimate: 85%); the middle value is on the limit's open side.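

Among the compounds shown here, no step from compound 3 to compound 4 can be read in this assay, as both compounds give only a limit: the limit of > 50000 nM in this assay, at which 4 of the 4 values shown sit. The compounds shown leave open whether hydrogen in place of hydroxy changes tolerance at all, and at what concentration any of the four compounds would become half-maximally cytotoxic.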